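The compounds below may be only part of what the source reports. "The series", "measured", "known", "first", "only" and "open" are said of these compounds alone.

Compound 1 `CNc1nc(SCc2ccc([N+](=O)[O-])cc2)c2ncn([C@@H]3O[C@H](CO)[C@@H](O)[C@H]3O)c2n1`: in an assay on K562 cells for displacement of a labelled ligand from Equilibrative nucleoside transporter 1 (Homo sapiens), read by flow cytometry, with a stated time of 45 min (a higher number here means a weaker inhibitor, a lower number a stronger inhibitor), compound 1 gives 24 nM.
Compound 2 `O=[N+]([O-])c1ccc(CSc2nc(NC3CCC3)nc3c2ncn3[C@@H]2O[C@H](CO)[C@@H](O)[C@H]2O)cc1`: in this assay compound 2 gives 33 nM.

Among the two numbers, compound 1 has the lowest, and the nearest is compound 2, which differs by a 1.4-fold higher number from compound 1 to compound 2 (0.14 log units; within the scatter), a gap that lies within the scatter; so the two cannot be ranked against each other.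

Compound 3 `O=[N+]([O-])c1ccc(CSc2nc(NCc3ccccc3)nc3c2ncn3[C@@H]2O[C@H](CO)[C@@H](O)[C@H]2O)cc1` has not yet been measured. It differs from compound 1 by phenyl in place of hydrogen on a saturated chain carbon bound to a nitrogen on an aromatic ring, so the methylamino of compound 1 becomes benzylamino. Within the data shown here, the one step that bears on this change is the replacement of methyl by cyclobutyl on the same nitrogen, which gave a 1.4-fold higher number from compound 1 to compound 2 (0.14 log units; within the scatter), a change within the scatter. Among the measured compounds shown here, a larger group on that nitrogen thus left the number essentially unchanged, though phenyl is a different kind of group and only one such step is known.

Compound 3 is therefore expected to stay close to compound 1, with an estimated step of a 1.5-fold higher number from compound 1 to compound 3 (0.16 log units; within the scatter). The estimate for compound 3 in this assay is 35 nM, with a range from 12 nM to 110 nM.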

Compound 3, inhibition constant: 247 nM
Beside the measured number, compound 3's estimate is 7.1-fold (0.85 log units) below it, outside the stated range (above it).
By their numbers in this assay, from the lowest: compounds 1 and 2 (each within the scatter of the next); then compound 3.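

This result shows that the substituent on this nitrogen does matter in this assay: methylamino to benzylamino gives a 10-fold higher number from compound 1 to compound 3 (1.01 log units; beyond the scatter), and cyclobutyl to benzyl gives a 7.5-fold higher number from compound 2 to compound 3 (0.87 log units; beyond the scatter), both beyond the scatter. The earlier step, a 1.4-fold higher number from compound 1 to compound 2 (0.14 log units; within the scatter), lay within the scatter and hinted that this position might accept a change of group with little effect, but that reading holds for cyclobutyl and does not extend to benzyl. No measurement here explains why the benzyl group behaves differently from the cyclobutyl group.

The three compounds cannot separate the effect of the aromatic ring from the effect of the carbon chain that holds it to the nitrogen, since a single benzyl group changes both at once compared with cyclobutyl. A cyclohexyl group would test a saturated ring of the same size as the phenyl, 2-phenylethyl would test a longer link to the phenyl, and a benzyl group carrying a carboxylic acid or an amine would show whether the number at this position responds to changes on the ring itself.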